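Amide Nitrogen Substitution in a Difluoro Indane Series

The source may report more compounds than this note shows. Statements on the series, on what has been measured and on what is new or still open speak of the compounds shown alone.

Compound 1 `CCN(C)C(=O)/C=C1\CCc2c(F)cc(F)cc21`: 100%
Compound 2 `CNC(=O)/C=C1\CCc2c(F)cc(F)cc21`: 100%
Compound 3 `NC(=O)/C=C1\CCc2c(F)cc(F)cc21`: 100%

In a functional assay on the whole organism with Mus musculus as the target, at a dose of 100 mg/kg by the intraperitoneal route (a higher number here means more inhibition at the dose given (going by the name of the read-out), a lower number less inhibition), compound 1 gives 100%, compound 2 gives 100% and compound 3 gives 100%. Compound 3 therefore stands level with compounds 1 and 2 at the digits reported; the numbers of the three are level. The three steps between them are no change at the digits printed from compound 1 to compound 2 (within the scatter), no change at the digits printed from compound 1 to compound 3 (within the scatter) and no change at the digits printed from compound 2 to compound 3 (within the scatter), all of them changes of substitution on the amide-type nitrogen that leave the read-out unchanged.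

Compound 4 `O=C(/C=C1\CCc2c(F)cc(F)cc21)NC1CC1` differs from compound 3 by cyclopropyl in place of hydrogen on an amide-type nitrogen. All three measured steps bear on this change, since each alters what sits on the same amide-type nitrogen, and none of them moved the read-out beyond the scatter. On that basis the expected step of no change at the digits printed from compound 3 to compound 4 (within the scatter) in this assay is no change beyond the scatter, in neither direction. The expected value for compound 4 in this assay is estimated at 100%, with a range from 88% to 100%.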

Compound 4, a percentage reported as inhibition, in the whole organism at one dose (the size of the read-out at that dose, not a potency): 100%
Compound 4: the middle estimate sits on the measured number at the digits printed; measured number inside the range.
By their numbers in this assay, from the lowest: compounds 1, 2, 3 and 4 (each within the scatter of the next).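

In this assay, among the compounds shown here, the amide-type nitrogen now carries a ring for the first time, where the earlier compounds held only hydrogen, methyl, or ethyl with methyl, and cyclopropyl in place of hydrogen gives no change at the digits printed from compound 3 to compound 4 (within the scatter) in this series. The same holds against the two alkyl-substituted amides: cyclopropyl in place of methyl gives no change at the digits printed from compound 2 to compound 4 (within the scatter), and cyclopropylamino in place of ethyl(methyl)amino on the carbonyl carbon gives no change at the digits printed from compound 1 to compound 4 (within the scatter), so the three-membered carbon ring joins hydrogen and the alkyl groups without separating from them in this read-out. No measurement is available that would explain this result.

Because all four compounds read the same at a single dose, the read-out gives no ranking among them and leaves open whether they would differ at a lower dose. It also leaves open whether a longer chain, a phenyl ring or a carboxylic acid on the same nitrogen would keep the read-out where compound 4 stands at 100% in this assay.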